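The compounds below may be only part of what the source reports. "The series", "measured", "known", "first", "only" and "open" are said of these compounds alone.

This account concerns three compounds sharing one core. Among the measured compounds shown here, compound 1 `COc1ccccc1/C=c1/[nH]c(=O)/c(=C\c2ccccc2OC)n(C)c1=O` is the only one with a firm number: in a functional assay on MCF7 cells (Homo sapiens) for cytotoxicity, read by CCK-8 assay, with a stated time of 72 h (a lower number here means a stronger inhibitor, a higher number a weaker inhibitor), compound 1 gives 9000 nM. Compound 2 `C=CCn1c(=O)/c(=C\c2ccc(Cl)c(Cl)c2)[nH]c(=O)/c1=C\c1ccccc1OC` stands differently, since in this assay compound 2 is reported as "not active" (no number reported), with no single number attached. Compound 3 `C=CCn1c(=O)/c(=C\c2ccc(C)cc2)[nH]c(=O)/c1=C\c1ccccc1OC` has not yet been tested in this assay. It differs from compound 2 in one place: 4-methylphenyl in place of 3,4-dichlorophenyl on a double-bonded chain carbon bound to an aromatic carbon. For the measured compounds named here, with no measured pair of this kind to draw on, the size and direction of the step from compound 2 to compound 3 in this assay cannot be anchored; what is known is that compound 2 gave no number at all, and compound 1, the one compound with a value, sits at 9000 nM. Compound 3 is therefore expected to remain a weak inhibitor in this assay, estimated at 15000 nM, within a range from 4000 nM to 60000 nM, with a real chance that only a limit is reported.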

Compound 3, half-maximal inhibitory concentration: "not active" (no number reported)
For compound 3 the study gives words and no number; there is nothing to compare the estimate with.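

In this assay compound 2 and compound 3 are both reported as "not active" with no number, so no step can be read between them. The compounds shown leave open whether 4-methylphenyl in place of 3,4-dichlorophenyl changes activity at all. Nothing shown bears on this result.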